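Replacing 4-bromophenyl with 4-methoxy-2-nitrophenyl

The source may hold more compounds than are shown below. What is called first, only, known or untested is meant among the compounds shown, and "the series" means these compounds.

Compound 1 `Cc1c(-n2cc(COc3ccc(/C=C/C(=O)c4cc5c(cc4O)OC(C)(C)CC5)cc3)nn2)cccc1[N+](=O)[O-]` gives 109000 nM
Compound 2 `COc1ccc(-n2cc(COc3ccc(/C=C/C(=O)c4cc5c(cc4O)OC(C)(C)CC5)cc3)nn2)c([N+](=O)[O-])c1` gives "not active" (no number reported)
Compound 3 `CC1(C)CCc2c(ccc(C(=O)/C=C/c3ccc(OCc4cn(-c5ccc(Br)cc5)nn4)cc3)c2O)O1` gives 136000 nM

All three were tested in a functional assay on HepG2 cells (Homo sapiens) for antiproliferative activity, read by MTT assay (a higher number here means a weaker inhibitor, a lower number a stronger inhibitor), for this account. Compound 3 lies within the scatter of compound 1, and compound 2 has no number for comparison. Compound 4 `COc1ccc(-n2cc(COc3ccc(/C=C/C(=O)c4ccc5c(c4O)CCC(C)(C)O5)cc3)nn2)c([N+](=O)[O-])c1` keeps the core of compound 3 and takes 4-methoxy-2-nitrophenyl in place of 4-bromophenyl on an aromatic nitrogen. Among the compounds with values here, no single-place step has been measured. On the core of compound 1 the same group is carried by compound 2, and compound 2 is reported as "not active" (no number reported) in this assay, so no gain is expected, and any change should stay within the scatter. The expected change is a 1.1-fold higher number from compound 3 to compound 4 (0.04 log units; within the scatter) by this estimate. Compound 4 is estimated at 150000 nM (expected range 70000 nM to 320000 nM).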

Compound 4, half-maximal inhibitory concentration: 120000 nM
Beside the measured number, compound 4's estimate is 1.3-fold (0.10 log units) above it; the range from low to high includes it.
By their numbers in this assay, from the lowest: compounds 1, 4 and 3 (each within the scatter of the next).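

On the shared core, 4-methoxy-2-nitrophenyl in place of 4-bromophenyl on the aromatic nitrogen gives a 1.1-fold lower number from compound 3 to compound 4 (0.05 log units; within the scatter) in this assay, so at this position the two groups cannot be told apart. Compound 4 carries a number, whereas compound 2, with the same group on the core of compound 1, is reported without one. Nothing at hand offers an explanation for this result. Still open, as far as these compounds go, is whether a phenyl ring bearing an amine or a carboxylic acid on this aromatic nitrogen would move the number beyond the scatter.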